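Second methoxy on compound 2: expected dose shift

The source may hold more compounds than are shown below. What is called first, only, known or untested is meant among the compounds shown, and "the series" means these compounds.

- compound 1 `CCC(=O)N(c1ccc(OC)cc1)C1CCCC1N(C)C` gives > 50 mg/kg; > 50 mg/kg (2 entries) (a limit, not a number; two entries)
- compound 2 `CCC(=O)N(c1cccc(OC)c1)C1CCCC1N(C)C` gives 4 mg/kg (one entry)

Among the compounds with values here, in a functional assay on the whole organism for positive allosteric modulation, with Mus musculus as the target (on this read-out higher numbers stand for an effect only at larger amounts of compound and lower numbers for an effect already at smaller amounts), compound 2 at 4 mg/kg holds the only number so far. Compound 3 `CCC(=O)N(c1ccc(OC)c(OC)c1)C1CCCC1N(C)C` differs from compound 2 by methoxy in place of hydrogen on an aromatic carbon and so carries a methoxy para to a large group. Compound 1 has its methoxy para to a large group too, and its > 50 mg/kg; > 50 mg/kg (2 entries) is a limit of the assay and not a number. A larger dose is therefore expected, and a 4.5-fold higher number from compound 2 to compound 3 (0.65 log units; beyond the scatter) is the estimated step, beyond the scatter. For compound 3 the estimated dose is 18 mg/kg with 5 mg/kg to 50 mg/kg as its range.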

Compound 3, dose for half-maximal effect: 10 mg/kg
Beside the measured number, compound 3's estimate is 1.8-fold (0.26 log units) above it; low and high end bracket the measured number.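

In this assay, within the data shown here, methoxy in place of hydrogen on an aromatic carbon, para to a large group, gives a 2.5-fold higher number from compound 2 to compound 3 (0.40 log units; beyond the scatter) as the first measured step, a modest one. Compound 1 gives > 50 mg/kg; > 50 mg/kg (2 entries) as a limit of the assay and not a number. Compound 3 carries methoxy at that same place and still gives 10 mg/kg as a real number, so a methoxy there does not by itself push the dose out of range.

No evidence on hand accounts for this step.

Open, as far as these compounds go, is whether an amine or an ethoxy at this place would give a smaller or larger step.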